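Aryl regained: from cyclohexyl back to a 4-propylphenyl

The source may report more compounds than this note shows. Statements on the series, on what has been measured and on what is new or still open speak of the compounds shown alone.

Measured in a functional assay on HeLa cells (Homo sapiens) for inhibition, read by sulforhodamine B assay; on this read-out lower numbers stand for stronger inhibition and higher numbers for weaker inhibition:
Compound 1 `O=C1C=C(Nc2ccc(I)cc2)C(=O)c2c1nc1n2[C@H]2OC[C@@H](O)[C@H]2OC1` gives 4070 nM.
Compound 2 `O=C1C=C(NC2CCCCC2)C(=O)c2c1nc1n2[C@H]2OC[C@@H](O)[C@H]2OC1` gives > 16000 nM, which is a limit of the assay and not a number.

Compound 2 thus stands at the limit of > 16000 nM in this assay, at which 1 of the 2 values shown sits, and only this limit is known for it. For the measured compounds named here, replacing the 4-iodophenyl on the amine nitrogen with cyclohexyl gave an at least 3.9-fold higher number from compound 1 to compound 2 (0.59 log units; beyond the scatter), the only measured step in the set. Compound 3 `CCCc1ccc(NC2=CC(=O)c3nc4n(c3C2=O)[C@H]2OC[C@@H](O)[C@H]2OC4)cc1` runs that change in the opposite direction: 4-propylphenyl in place of cyclohexyl on an amine nitrogen. Going by the values given here, the one step that bears on it shows an aryl giving way to cyclohexyl with an at least modest rise in the number, so the return of an aryl group is expected to give an at least 3.2-fold lower number from compound 2 to compound 3 (0.50 log units; beyond the scatter) in this assay, towards a lower number, somewhere near where compound 1 sits. Compound 3 is therefore estimated at 5000 nM, with a range from 2000 nM to 15000 nM.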

Compound 3, half-maximal inhibitory concentration: 4990 nM
The estimate for compound 3 lay 1.0-fold (0.00 log units) above the measured number, and the stated range covers the measured number.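

Putting 4-propylphenyl in place of cyclohexyl on the amine nitrogen gave an at least 3.2-fold lower number from compound 2 to compound 3 (0.50 log units; beyond the scatter) in this assay, so the gap to cyclohexyl is not peculiar to 4-iodophenyl but also appears with a second aryl group. Propyl in place of iodo on an aromatic carbon gave a 1.2-fold higher number from compound 1 to compound 3 (0.09 log units; within the scatter) in this assay, so this assay does not separate these two aryl groups. The step from cyclohexyl gives only a bound, because compound 2 has a limit and not a number: the limit of > 16000 nM in this assay, at which 1 of the 3 values shown sits.

Still open, going by these compounds, is how an unsubstituted phenyl, a 4-methoxyphenyl or a benzyl on the amine nitrogen would compare. Also open, on these data alone, is how far the true number for compound 2 lies from those of compound 1 and compound 3.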